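Bromo for Iodo on the Arylamino Group of Compound 3

A few compounds are considered here, and "the series" means these few. Any claim that something is new, unique, unknown or untested is made for them only; others in the source may bear on it.

Compound 3 `O=C(C1=C(Nc2ccc(I)cc2)C(=O)N(CCCn2ccnc2)C1c1ccc(Br)cc1)c1ccccc1` gives 19400 nM in a functional assay on NCI-H1299 cells (Homo sapiens) for antiproliferative activity, read by MTT assay, with a stated time of 72 h; on this read-out higher numbers stand for weaker inhibition and lower numbers for stronger inhibition. Among the measured compounds it stands second highest; its nearest neighbour is compound 1 `O=C(C1=C(O)C(=O)N(CCCn2ccnc2)C1c1ccc(Br)cc1)c1ccccc1`, which gives 20000 nM, and the furthest is compound 2 `CCCCOC1=C(C(=O)c2ccccc2)C(c2ccc(Br)cc2)N(CCCn2ccnc2)C1=O`, which gives 17100 nM. The steps of a 1.0-fold lower number from compound 1 to compound 3 (0.01 log units; within the scatter) and a 1.1-fold higher number from compound 2 to compound 3 (0.05 log units; within the scatter) are both within the scatter, as is a 1.2-fold lower number from compound 1 to compound 2 (0.07 log units; within the scatter). Compound 4 `O=C(C1=C(Nc2ccc(Br)cc2)C(=O)N(CCCn2ccnc2)C1c1ccc(Br)cc1)c1ccccc1` differs from compound 3 by bromo in place of iodo on an aromatic carbon. Within the data shown here, no measured step exchanges one halogen for another on this ring, so the change has no direct precedent here; what the measured steps do show is that the group on the double-bonded ring carbon, whether hydroxy, butoxy or (4-iodophenyl)amino, left this assay unchanged beyond the scatter. A small alteration inside that group is therefore expected to give no step beyond the scatter, so a 1.0-fold higher number from compound 3 to compound 4 (0.00 log units; within the scatter) is the expected step. Compound 4 is expected to give 19500 nM in this assay, with a range from 10000 nM to 40000 nM.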

Compound 4, half-maximal inhibitory concentration: 19300 nM
Beside the measured number, compound 4's estimate is 1.0-fold (0.00 log units) above it; measured number inside the range.
By their numbers in this assay, from the lowest: compounds 2, 4, 3 and 1 (each within the scatter of the next).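

In this assay, among these compounds, the first exchange of one halogen for another on this ring gives no step beyond the scatter (a 1.0-fold lower number from compound 3 to compound 4 (0.00 log units; within the scatter)), so within this pair the assay does not separate bromo from iodo. The (4-bromophenyl)amino group also stays within the scatter of the other two groups on the double-bonded ring carbon, butoxy (a 1.1-fold higher number from compound 2 to compound 4 (0.05 log units; within the scatter)) and hydroxy (a 1.0-fold lower number from compound 1 to compound 4 (0.02 log units; within the scatter)), which extends the flat picture to a second arylamino group. Nothing measured here accounts for this flatness.

The compounds shown leave open whether a carboxylic acid or an amine in place of bromo on the aromatic carbon would give a step beyond the scatter. They also leave open whether a longer chain elsewhere on the shared core would do so.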